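The source may hold more compounds than are shown below. What is called first, only, known or untested is meant among the compounds shown, and "the series" means these compounds.

Working notes on the series.

Two members of the series have a number in an assay on cells for inhibition of Voltage-dependent T-type calcium channel subunit alpha-1I (Homo sapiens), read by patch clamp (a higher number here means a weaker inhibitor, a lower number a stronger inhibitor), so far. Compound 1 `CN(C)CCCCCSC1=Nc2ccccc2C(CC(=O)NCc2ccccc2)N1c1ccc(-c2ccc(F)cc2)cc1` gives 9060 nM in this assay. Compound 2 `O=C(CC1c2ccccc2N=C(SCCCCCN2CCCC2)N1c1ccc(-c2ccc(F)cc2)cc1)NCc1ccc(F)cc1` gives 19800 nM in this assay, the higher of the two numbers; compound 1 stands nearest to it, and the gap between compound 1 and compound 2 lies beyond the scatter. Within the data shown here, compound 1 and compound 2 differ in more than one place, so no single step between them can be read.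

Compound 3 `O=C(CC1c2ccccc2N=C(SCCCCCN2CCCC2)N1c1ccc(-c2ccc(F)cc2)cc1)NCc1ccccc1` is not yet measured in this assay. It differs from compound 2 in one place: hydrogen in place of fluoro on an aromatic carbon, para to a large group. Among the measured compounds shown here, no measured pair shows this change on its own, so its size is unknown here. From compound 2 to compound 3 a small step is expected, a 1.4-fold lower number from compound 2 to compound 3 (0.15 log units; within the scatter), most likely not beyond the scatter, with a slight lean toward a lower number. For compound 3 the estimate in this assay is 14000 nM, with a range from 5000 nM to 35000 nM.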

Compound 3, half-maximal inhibitory concentration: 5100 nM
Beside the measured number, compound 3's estimate is 2.7-fold (0.44 log units) above it, and the stated range covers the measured number.
By their numbers in this assay, from the lowest: compounds 3 and 1 (each within the scatter of the next); then compound 2.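

In this assay, among these compounds, the change from 4-fluorobenzyl to benzyl gives the first readable step at this position, a 3.9-fold lower number from compound 2 to compound 3 (0.59 log units; beyond the scatter), so hydrogen in place of fluoro on this aromatic carbon moves the number by more than the scatter, at least with pyrrolidin-1-yl at the end of the chain. The second readable step, a 1.8-fold lower number from compound 1 to compound 3 (0.25 log units; within the scatter), concerns the amine on the saturated chain: with the benzyl amide held constant, pyrrolidin-1-yl in place of dimethylamino gives no separation between the two compounds. Nothing measured on these compounds accounts for either step.

As far as these compounds go, each change is seen only once and in a single setting, so it remains open whether removing the fluoro would give a similar step with dimethylamino at the end of the chain. Also open, from the compounds shown here alone, is how other groups would read in this assay, such as chloro or methoxy at the same place on the benzyl ring, or a piperidine or a shorter chain in place of the present amine and chain.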